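The source may hold more compounds than are shown below. What is called first, only, known or untested is meant among the compounds shown, and "the series" means these compounds.

For the measured compounds named here, in a functional assay on COR-L23 cells (Homo sapiens) for antiproliferative activity, read by CellTiter-Glo, with a stated time of 72 h (on this read-out higher numbers stand for weaker inhibition and lower numbers for stronger inhibition), compound 1 (`C[C@H](NC(=O)C1CCOCC1)c1ccc(NC(=O)N2CC(c3cccnc3)C2)cc1`) gives 58 nM, the lower of the two numbers so far. Compound 2 (`CCC(=O)N[C@@H](C)c1ccc(NC(=O)N2CC(c3cccnc3)C2)cc1`) gives 120 nM. Ethyl in place of oxan-4-yl on a carbonyl carbon accounts for a 2.1-fold higher number from compound 1 to compound 2 (0.32 log units; beyond the scatter).

Compound 3 (`C[C@H](NC(=O)C1CCOCC1)c1ccc(NC(=O)N2CC(c3ccc(N)nc3)C2)cc1`) keeps compound 1 except for pyridin-3-yl to 6-aminopyridin-3-yl: amino in place of hydrogen on an aromatic carbon. This is amino in place of hydrogen on an aromatic carbon, next to the ring nitrogen. Going by the values given here, the only measured step, a 2.1-fold higher number from compound 1 to compound 2 (0.32 log units; beyond the scatter), lies at the carbonyl carbon and not on the pyridin-3-yl group, so it offers only a rough size guide. Among the compounds with values here, no measured compound tests this change, so direction and size are judgement: a step to a higher number in this assay, probably larger than that modest one, is expected, with wide uncertainty.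

The expected step is an 8.6-fold higher number from compound 1 to compound 3 (0.94 log units; beyond the scatter). For compound 3 the estimated value is 500 nM, within an expected range of 70 nM to 4000 nM.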

Compound 3, half-maximal inhibitory concentration: 110 nM
Beside the measured number, compound 3's estimate is 4.5-fold (0.66 log units) above it; the range from low to high includes it.
By their numbers in this assay, from the lowest: compounds 1, 3 and 2 (each within the scatter of the next, the first and the last beyond it).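

In this assay, amino in place of hydrogen on an aromatic carbon, next to the ring nitrogen, gives a 1.9-fold higher number from compound 1 to compound 3 (0.28 log units; within the scatter). For the compounds shown here, this is the first measured change on the pyridin-3-yl side of the series, and it shows that 6-aminopyridin-3-yl is tolerated here, with the added amino group producing no step beyond the scatter. The data shown hold no independent measurement that bears on why this change has so small an effect.

The compounds shown leave open whether a larger group at this place, such as dimethylamino or methoxy, would be tolerated in the same way. They also leave open whether the amino group would give a similar result when paired with the ethyl on the carbonyl carbon.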